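A few compounds are considered here, and "the series" means these few. Any claim that something is new, unique, unknown or untested is made for them only; others in the source may bear on it.

Three compounds that share one core have been examined in a toxicity assay on MT2 cells (Homo sapiens) for cytotoxicity (on this read-out lower numbers stand for higher toxicity in this test and higher numbers for lower toxicity in this test), and all three sit at the weak end of that read-out. For compound 1 `Cc1nc(C)c([C@H](OC(C)(C)C)C(=O)O)c(N2CCC(C)(C)CC2)c1-c1ccc2c(c1)CC[C@H](Cc1ccc(F)cc1)O2` the outcome is only the limit >= 22000 nM of the measurement, not a number. For compound 2 `Cc1nc(C)c([C@H](OC(C)(C)C)C(=O)O)c(N2CCC(C)(C)CC2)c1C1=CCN(CCCc2ccc(F)cc2)CC1` the outcome is again the limit >= 22000 nM and not a number. Among the measured compounds shown here, compound 3 `Cc1cccc(Cl)c1CN1CCc2cc(-c3c(C)nc(C)c([C@H](OC(C)(C)C)C(=O)O)c3N3CCC(C)(C)CC3)ccc2C1` is the single compound with a real number, as compound 3 gives 22500 nM in this assay when the cells are exposed to it. That number lies right at the limit of >= 22000 nM in this assay, at which 2 of the 3 values shown sit, and so compound 3 stands where the other two stand, with nothing setting it apart.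

Compound 4 `Cc1nc(C)c([C@H](OC(C)(C)C)C(=O)O)c(N2CCC(C)(C)CC2)c1-c1ccc2c(c1)CCN(c1nccc(-c3cnccn3)n1)C2` has not been measured yet. It differs from compound 3 in one place a group of 12 heavy atoms (8 carbon, 4 nitrogen; 2 six-membered aromatic rings with 2 hetero atoms each) in place of a group of 9 heavy atoms (8 carbon, 1 chlorine; one six-membered aromatic ring of carbon only), on an amine nitrogen in a ring and nothing measured here shows how such a change moves this read-out. The expectation is a step from compound 3 to compound 4 of a 1.0-fold lower number from compound 3 to compound 4 (0.01 log units; within the scatter) and so no movement beyond the usual scatter. Compound 4 is expected to give about 22000 nM with a range from 11000 nM to 44000 nM in this assay and the assay may well report only a limit once more.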

Compound 4, half-maximal cytotoxic concentration: >= 17000 nM
Compound 4 ended at the assay's limit; the forecaster's own chance of this, stated with the estimate: 60%; the middle value is on the limit's open side.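

Compound 4 gives only a limit rather than a number, so no step can be read between compound 3 and compound 4. The compounds shown leave open whether any group on an amine nitrogen in a ring moves the read-out in this assay at all.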